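The source may hold more compounds than are shown below. What is called first, only, known or untested is meant among the compounds shown, and "the series" means these compounds.

Measured so far: compound 1 `CCS(=O)(=O)Nc1cccnc1-c1ccc(C(=O)Nc2ccc(C(C)(C)C)cc2)cc1` and compound 2 `CC(C)(C)c1ccc(NC(=O)c2ccc(-c3ncccc3C(=N)N)cc2)cc1`. In a functional assay for antagonist activity at transient receptor potential cation channel subfamily V member 1 (Homo sapiens), read by FLIPR (a higher number here means a weaker inhibitor, a lower number a stronger inhibitor), compound 1 gives 49 nM. In this assay compound 2 reaches only a limit of the assay, > 4000 nM.

Compound 2 thus stands at the limit of > 4000 nM in this assay, at which 1 of the 2 values shown sits, rather than at a number, and it is the weaker of the two, since the step of an at least 81-fold higher number from compound 1 to compound 2 (1.91 log units; beyond the scatter) carries the series from a measured value to that limit.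

The unmeasured compound 3 `CC(C)(C)c1ccc(NC(=O)c2ccc(-c3ncccc3-c3ncc[nH]3)cc2)cc1` differs from compound 2 in one place: a group of 5 heavy atoms (3 carbon, 2 nitrogen; one five-membered aromatic ring with 2 hetero atoms) in place of a group of 3 heavy atoms (1 carbon, 2 nitrogen; no ring), on an aromatic carbon, the entering 1H-imidazol-2-yl sitting ortho to a large group and two atoms from the ring nitrogen. Among the compounds with values here, only one measured step touches this position, an at least 81-fold higher number from compound 1 to compound 2 (1.91 log units; beyond the scatter), and it was large; but it concerns a different pair of groups, and no measured compound carries the 1H-imidazol-2-yl, so the data give no direct size for the present change. With compound 2 at a limit, any step from it can only be estimated. Compound 3 is expected to remain a weak inhibitor, with an estimate of 3000 nM, between 500 nM and 20000 nM. The step of an at least 1.3-fold lower number from compound 2 to compound 3 (0.12 log units; that floor lies within the scatter) is therefore expected to be small at best.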

Compound 3, half-maximal inhibitory concentration: 3670 nM
Compound 3: middle estimate off by 1.2-fold (0.09 log units), on the low side; the measured number falls inside the stated range.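

Within the data shown here, with 1H-imidazol-2-yl on this aromatic carbon, ortho to a large group and two atoms from the ring nitrogen, the position gives a measured number for a replacement of (ethylsulfonyl)amino for the first time in this assay, and the cost of that replacement is now a large step of known size rather than a floor: a 75-fold higher number from compound 1 to compound 3 (1.87 log units; beyond the scatter). Both replacements shown, the ringless group of compound 2 and the five-membered aromatic ring of compound 3, therefore leave the compounds far from compound 1, so the large loss does not belong to the ringless group alone. Compound 2 stands at a limit of the assay: the limit of > 4000 nM in this assay, at which 1 of the 3 values shown sits. The step of an at least 1.0-fold lower number from compound 2 to compound 3 (0.03 log units; that floor lies within the scatter) is therefore only a floor and cannot be read as a size.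

The compounds shown leave open whether any group other than (ethylsulfonyl)amino can hold this position near the 49 nM of compound 1, since they include no methylsulfonylamino, no plain amine and no carboxylic acid here. They also leave open whether that value rests on the sulfonyl unit or on its ethyl chain, which a longer chain on the same sulfonyl would help to separate.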